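The source may report more compounds than this note shows. Statements on the series, on what has been measured and on what is new or still open speak of the compounds shown alone.

Compound 1 `COc1cccc(CNCCCNc2ccnc3cc(Oc4ccc(Cl)cc4)ccc23)c1O` gives 9.28 in a physicochemical assay for acid dissociation. Compound 2 `COc1ccc(Oc2ccc3c(NCCCNCc4cccc(OC)c4O)ccnc3c2)cc1` gives 9.28 in this assay, level with compound 1 at the digits shown. The step of no change at the digits printed from compound 1 to compound 2 (within the scatter), methoxy in place of chloro on an aromatic carbon, stayed within the scatter. Compound 3 `COc1cccc(CNCCCNc2ccnc3cc(Oc4ccc(F)cc4)ccc23)c1O` differs from compound 2 by fluoro in place of methoxy on an aromatic carbon. For the measured compounds named here, only the step of no change at the digits printed from compound 1 to compound 2 (within the scatter) bears on this change, and it was flat, which leaves no shift beyond the scatter to expect. The expected step is therefore no change at the digits printed from compound 2 to compound 3 (within the scatter). For compound 3 the estimate is 9.28, with a range of 9 to 9.55.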

Compound 3, acid dissociation constant: 9.28
The estimate for compound 3 equals the measured number at the digits printed, within the range that was stated.
By their numbers in this assay, from the lowest: compounds 1, 2 and 3 (each within the scatter of the next).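

In this assay, fluoro on this aromatic carbon, para to a large group, gives no change at the digits printed from compound 2 to compound 3 (within the scatter) and no change at the digits printed from compound 1 to compound 3 (within the scatter). Three groups at this position now share one reading, so the flat result no longer rests on the chloro and methoxy pair alone. Nothing available gives a reason for this flatness. The compounds shown leave open whether an amine or a carboxylic acid at this position would also read level with these three, and whether changes elsewhere on the shared core would move the read-out.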